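Compound 4 and the fluoro limit

A few compounds are considered here, and "the series" means these few. Any claim that something is new, unique, unknown or untested is made for them only; others in the source may bear on it.

Measured in a functional assay on HeLa cells (Homo sapiens) for inhibition, read by MTT assay, with a stated time of 72 h (on this read-out higher numbers stand for weaker inhibition and lower numbers for stronger inhibition), so far:
- compound 1 `COc1cc(NC(C)CCCNC(=O)NNC(=O)Nc2ccc(F)cc2)c2ncccc2c1` gives >= 250000 nM as a limit of the assay
- compound 2 `COc1cc(NC(C)CCCNC(=O)NNC(=O)Nc2ccc(Br)cc2)c2ncccc2c1` gives 101000 nM as a number
- compound 3 `COc1cc(NC(C)CCCNC(=O)NNC(=O)Nc2cccc(F)c2)c2ncccc2c1` gives > 250000 nM as a limit of the assay

Compound 3 gives > 250000 nM and this is a limit, not a number. Compound 4 `COc1cc(NC(C)CCCNC(=O)NNC(=O)Nc2cccc(C(F)(F)F)c2)c2ncccc2c1` keeps everything in compound 3 except one group: trifluoromethyl in place of fluoro on an aromatic carbon that is, trifluoromethyl in place of fluoro on an aromatic carbon, meta to a large group.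

Among the measured compounds shown here, three measured steps bear on this. Bromo in place of fluoro gave an at least 2.4-fold lower number from compound 1 to compound 2 (0.39 log units; beyond the scatter) and the return to a fluorophenyl gave an at least 2.4-fold higher number from compound 2 to compound 3 (0.39 log units; beyond the scatter) so compound 2 alone has left the limit. Moving the fluoro gave a step that the two limits leave unreadable from compound 1 to compound 3 and so says nothing about place. Compound 2 carries a 4-bromophenyl rather than a 3-(trifluoromethyl)phenyl, which makes it only a loose guide.

A modest move to a lower number is expected in this assay because an at least 2.4-fold lower number from compound 1 to compound 2 (0.39 log units; beyond the scatter) is the only readable replacement of fluoro on this aryl group. The expected step is an at least 1.9-fold lower number from compound 3 to compound 4 (0.28 log units; that floor lies within the scatter) and it remains an estimate set against a limit. The estimate for compound 4 is 130000 nM with an expected range from 50000 nM to 250000 nM for this measurement.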

Compound 4, half-maximal inhibitory concentration: 4900 nM
For compound 4 the middle estimate is 27-fold (1.42 log units) above the measured one; the measured number lies below the stated range.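

In this assay, among the compounds shown here, trifluoromethyl on this aromatic carbon, meta to a large group, gives the first steps in the set that read as large: an at least 51-fold lower number from compound 3 to compound 4 (1.70 log units; beyond the scatter), and a 21-fold lower number from compound 2 to compound 4 (1.31 log units; beyond the scatter), so the only earlier compound with a number is also passed. The first of these steps is a floor, as compound 3 stands at a limit: the limit of > 250000 nM in this assay, at which 1 of the 4 values shown sits. The step of an at least 51-fold lower number from compound 1 to compound 4 (1.70 log units; beyond the scatter) is a floor too, as compound 1 also stands at a limit: the limit of >= 250000 nM in this assay, at which 1 of the 4 values shown sits.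

The compounds shown leave open whether trifluoromethyl would keep this gain at another place on the ring. They also leave open whether a nitrile or a carboxylic acid on this same carbon would give a similar step, so the result cannot yet be read as more than one group at one place.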